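This account rests on a few compounds, and the source may have more. Where it says the series, first, only, none or still open, it means among the compounds named here.

Compound 1 `C=CC1C(=O)N(c2cc(OC)c(OC)c(OC)c2)C1c1ccc(SCC)cc1`: 257 nM
Compound 2 `COc1ccc(C2C(C3CC3)C(=O)N2c2cc(OC)c(OC)c(OC)c2)cc1`: 107 nM

Both values come from a functional assay on HT-29 cells (Homo sapiens) for inhibition, read by sulforhodamine B assay, with a stated time of 72 h; on this read-out lower numbers stand for stronger inhibition and higher numbers for weaker inhibition. Compound 2, at 107 nM, holds the lower of the two numbers, and compound 1, at 257 nM, stands higher by more than the scatter. The next compound to consider is compound 3 `C=CC1C(=O)N(c2cc(OC)c(OC)c(OC)c2)C1c1ccc(OC)cc1`, which keeps the 4-methoxyphenyl group of compound 2 and differs from it in one place: vinyl in place of cyclopropyl on a saturated ring carbon. Among the compounds with values here, compound 1 also carries vinyl, but it differs from compound 2 in more than one place, so no measured pair isolates this change. The step expected in this assay is small, leaning towards a lower number and probably not beyond the scatter. The expected change is a 1.5-fold lower number from compound 2 to compound 3 (0.18 log units; within the scatter). For compound 3 the estimated value is 70 nM, with an expected range of 15 nM to 300 nM.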

Compound 3, half-maximal inhibitory concentration: 10 nM
The estimate for compound 3 lay 7.0-fold (0.85 log units) above the measured number, and the stated range ends above it.
By their numbers in this assay, from the lowest: compound 3; then compound 2; then compound 1.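

In this assay vinyl in place of cyclopropyl on the saturated ring carbon gives an 11-fold lower number from compound 2 to compound 3 (1.03 log units; beyond the scatter) and shows that this position, next to the ring atom that bears the 4-methoxyphenyl group, responds strongly to an exchange between two carbon-only groups. With vinyl held fixed, methoxy in place of ethylsulfanyl on the aromatic carbon gives a 26-fold lower number from compound 1 to compound 3 (1.41 log units; beyond the scatter) and isolates a change that the difference between the two earlier compounds could not separate. No measurement at hand accounts for either step.

Still open, from the compounds shown here alone, is how an ethyl group or a longer chain such as allyl would read at the saturated ring carbon. Also open, going by these compounds, is whether an amine or a hydroxyl group on the aromatic carbon could stand in for methoxy.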